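Methyl for fluoro on the para-substituted phenyl ring

This account rests on a few compounds, and the source may have more. Where it says the series, first, only, none or still open, it means among the compounds named here.

Measured so far:
compound 1, `CCCc1cc2ccccc2nc1-c1cc(-c2ccc(F)cc2)no1`, 42200 nM
compound 2, `CCCCc1cc2ccccc2nc1-c1cc(-c2ccc(F)cc2)no1`, 26300 nM

Compound 1 gives the highest of the two numbers in a functional assay on PC-3 cells (Homo sapiens) for inhibition, read by MTT assay, with a stated time of 24 h (a lower number here means a stronger inhibitor, a higher number a weaker inhibitor), and its nearest neighbour is compound 2, reached by a 1.6-fold lower number from compound 1 to compound 2 (0.21 log units; within the scatter), which is a change on the saturated chain rather than on the aromatic ring. The unmeasured compound 3, `CCCc1cc2ccccc2nc1-c1cc(-c2ccc(C)cc2)no1`, differs from compound 1 by methyl in place of fluoro on an aromatic carbon, with the rest of the shared core kept as it stands. Among the measured compounds shown here, no measured step touches this ring: the only step available, from compound 1 to compound 2, sits on the chain and is itself within the scatter, so it says nothing about an exchange on the aromatic carbon. For the measured compounds named here, with no step bearing on the change, the expectation for compound 3 in this assay is a number close to that of compound 1, and the estimated step of a 1.1-fold lower number from compound 1 to compound 3 (0.02 log units; within the scatter) is expected to stay within the scatter. Compound 3 is therefore estimated at 40000 nM, with a range from 15000 nM to 110000 nM.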

Compound 3, half-maximal inhibitory concentration: > 100000 nM
Compound 3: a limit, no number (the forecaster's own chance of this, stated with the estimate: 25%); middle value at least 2.5-fold (0.39 log units) from the limit.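

In this assay, the exchange of 4-fluorophenyl for 4-methylphenyl gives an at least 2.3-fold higher number from compound 1 to compound 3 (0.37 log units; beyond the scatter), so a single-atom change on this aromatic carbon moves the number beyond the scatter, which the step on the chain, a 1.6-fold lower number from compound 1 to compound 2 (0.21 log units; within the scatter), did not do. Compound 3 gives > 100000 nM, which is a limit of the assay and not a number. The step therefore has a known lower end but no known size, and the series now shows that this aromatic carbon does not tolerate every exchange of one heavy atom for another: the limit of > 100000 nM in this assay, at which 1 of the 3 values shown sits.

The compounds shown leave open whether hydrogen, chloro, methoxy or an amine on this aromatic carbon would keep the number close to that of compound 1 or carry it to the limit, as methyl does. They also leave open whether methyl in place of fluoro on the longer chain of compound 2 would give a step in the same direction, or whether a longer chain still would change the picture.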